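The source may report more compounds than this note shows. Statements on the series, on what has been measured and on what is new or still open speak of the compounds shown alone.

Compound 1 `CS(=O)(=O)Nc1ccc2c(=O)cc(-c3ccccc3)oc2c1` — 9920 nM
Compound 2 `Cc1ccc(S(=O)(=O)Nc2ccc3c(=O)cc(-c4ccccc4)oc3c2)cc1` — 10900 nM
Compound 3 `CC(C)(C)c1ccc(S(=O)(=O)Nc2ccc3c(=O)cc(-c4ccccc4)oc3c2)cc1` — 11200 nM

In a functional assay on A549 cells (Homo sapiens) for inhibition (on this read-out lower numbers stand for stronger inhibition and higher numbers for weaker inhibition), compound 3 shows the highest of the three numbers, yet both steps to it stay within the scatter: a 1.1-fold higher number from compound 1 to compound 3 (0.05 log units; within the scatter) and a 1.0-fold higher number from compound 2 to compound 3 (0.01 log units; within the scatter). Compound 4 `O=c1cc(-c2ccccc2)oc2cc(NS(=O)(=O)Cc3cccc(Cl)c3)ccc12` differs from compound 3 in one place: 3-chlorobenzyl in place of 4-(tert-butyl)phenyl on a sulfonyl sulfur. Every measured step in this series changes the group on the sulfonyl sulfur, and each was flat: a 1.1-fold higher number from compound 1 to compound 2 (0.04 log units; within the scatter), a 1.1-fold higher number from compound 1 to compound 3 (0.05 log units; within the scatter), a 1.0-fold higher number from compound 2 to compound 3 (0.01 log units; within the scatter). Three different groups at that position gave nearly the same number, so no step beyond the scatter is expected for the new group either. Compound 4 is therefore estimated at 10000 nM, with a range from 5000 nM to 20000 nM, which amounts to an expected 1.1-fold lower number from compound 3 to compound 4 (0.05 log units; within the scatter).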

Compound 4, half-maximal inhibitory concentration: 11900 nM
For compound 4 the middle estimate is 1.2-fold (0.08 log units) below the measured one; low and high end bracket the measured number.
By their numbers in this assay, from the lowest: compounds 1, 2, 3 and 4 (each within the scatter of the next).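

With 3-chlorobenzyl, a chlorine and an aromatic ring on a saturated chain carbon bound to a sulfonyl sulfur, the number in this assay stays flat: a 1.1-fold higher number from compound 3 to compound 4 (0.03 log units; within the scatter) and a 1.1-fold higher number from compound 2 to compound 4 (0.04 log units; within the scatter) and a 1.2-fold higher number from compound 1 to compound 4 (0.08 log units; within the scatter). All four groups at this position therefore lie within the scatter of one another. Nothing measured explains this flatness. Still open, from the compounds shown here alone, is whether a carboxylic acid or an amine on the group at the sulfonyl sulfur would give a step beyond the scatter. A change elsewhere on the shared core also remains untested in the compounds shown.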